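Thiophene carboxamide series: amide aryl swap on the urea scaffold

This account rests on a few compounds, and the source may have more. Where it says the series, first, only, none or still open, it means among the compounds named here.

Measured so far:
- compound 1 `Cc1ccc(C(=O)Nc2sc3c(c2C(N)=O)CCN(Cc2ccc(Cl)cc2Cl)C3)cc1` — 25500 nM
- compound 2 `NC(=O)c1c(NC(=O)c2ccccc2F)sc2c1CCN(C(=O)Nc1ccccc1Cl)C2` — 49600 nM

Both compounds were examined in a functional assay on MKN-74 cells (Homo sapiens) for antiproliferative activity, with a stated time of 24 h; a higher number here means a weaker inhibitor, a lower number a stronger inhibitor. Compound 1 gives 25500 nM there. Compound 2 gives 49600 nM in this assay, the highest number recorded so far, but its nearest neighbour is compound 1 and the gap between the pair lies within the scatter, so no order between them can be claimed. The pair differ in more than one place, so nothing is said about any single change between them.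

Compound 3 `Cc1ccc(C(=O)Nc2sc3c(c2C(N)=O)CCN(C(=O)Nc2ccccc2Cl)C3)cc1` is not yet measured. It keeps the core of compound 2 with its urea substituent and changes only the acyl group on the amide: 4-methylphenyl in place of 2-fluorophenyl on a carbonyl carbon. Going by the values given here, no step between measured compounds isolates this exchange. Among the compounds with values here, the only guide is that compound 1, which also carries the 4-methylphenyl carbonyl, sits at a similar level to compound 2, so no step beyond the scatter is expected from compound 2 to compound 3 a 1.6-fold lower number from compound 2 to compound 3 (0.19 log units; within the scatter). Compound 3 is therefore estimated at 32000 nM, with a range from 10000 nM to 100000 nM.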

Compound 3, half-maximal inhibitory concentration: 27600 nM
Compound 3: the middle estimate sits 1.2-fold (0.06 log units) above what was measured, within the range that was stated.
By their numbers in this assay, from the lowest: compounds 1, 3 and 2 (each within the scatter of the next).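

In this assay, 4-methylphenyl in place of 2-fluorophenyl on a carbonyl carbon whose other neighbours are amide-type nitrogen gives a 1.8-fold lower number from compound 2 to compound 3 (0.25 log units; within the scatter) and, with the urea substituent held constant, this single exchange has no readable effect on the number. At the second place, an amine nitrogen in a ring, (2-chlorophenyl)carbamoyl in place of 2,4-dichlorobenzyl gives a 1.1-fold higher number from compound 1 to compound 3 (0.03 log units; within the scatter), so with the 4-methylphenyl carbonyl held constant, this exchange also leaves no readable difference, and neither place yet shows a preference between the groups compared. No supporting data bear on either exchange.

From the compounds shown here alone, both exchanges stay among carbon-ring aryl or benzyl-type groups without net charge, so it remains open whether a carboxylic acid, an amine or a longer alkyl chain at either place would give a step beyond the scatter. Compounds 1, 2 and 3 lie within the scatter of one another, so the series does not yet show which of the two places, if either, can shift antiproliferative activity in this cell line.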